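Replacing the thiadiazole of compound 2 with a fluoropyridine

A few compounds are considered here, and "the series" means these few. Any claim that something is new, unique, unknown or untested is made for them only; others in the source may bear on it.

Measured compounds:
compound 1, `CCC(C)(C)Cc1c[nH]c(CCc2ccc(-c3cccc(N)n3)cc2)n1`, 3.9 nM
compound 2, `CCC(C)(C)Cc1c[nH]c(CCc2ccc(-c3csnn3)cc2)n1`, 11 nM
compound 3, `CCC(C)(C)Cc1c[nH]c(CCc2ccc(-n3ncnn3)cc2)n1`, 25 nM

In a functional assay on HEK293 cells for agonist activity at Bombesin receptor subtype-3 (Mus musculus), read by luminescence and calcium flux, with a stated time of 10 min (a lower number here means that less compound is needed, a higher number that more compound is needed for the effect), compound 2 stands second highest of the three numbers. Its nearest neighbour is compound 3, reached by a 2.3-fold higher number from compound 2 to compound 3 (0.36 log units; beyond the scatter); the furthest is compound 1, from which compound 2 is reached by a 2.8-fold higher number from compound 1 to compound 2 (0.45 log units; beyond the scatter). All three share one core and differ only in the ring on the aromatic carbon of the phenyl ring.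

Compound 4, `CCC(C)(C)Cc1c[nH]c(CCc2ccc(-c3ccc(F)cn3)cc2)n1`, is not yet measured. It differs from compound 2 as follows: 5-fluoropyridin-2-yl in place of 1,2,3-thiadiazol-4-yl on an aromatic carbon. The step that bears most on this change is a 2.8-fold higher number from compound 1 to compound 2 (0.45 log units; beyond the scatter), where the six-membered 6-aminopyridin-2-yl gave a lower number than the five-membered 1,2,3-thiadiazol-4-yl. The 5-fluoropyridin-2-yl entering in compound 4 shares the six-membered pyridine ring of compound 1 but lacks its amino group, so a modest step toward a lower number is expected in this assay, yet not the full distance back to compound 1. Compound 4 is therefore expected to give about 6 nM in this assay, within 2.5 nM to 15 nM. This estimate means the expected step of a 1.8-fold lower number from compound 2 to compound 4 (0.26 log units; within the scatter).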

Compound 4, half-maximal effective concentration: 16 nM
Estimate against measurement, compound 4: 2.7-fold (0.43 log units) below; the measured number lies above the stated range.
By their numbers in this assay, from the lowest: compound 1; then compounds 2, 4 and 3 (each within the scatter of the next, the first and the last beyond it).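

In this assay, the six-membered 5-fluoropyridin-2-yl does not set itself apart from the five-membered rings: both a 1.5-fold higher number from compound 2 to compound 4 (0.16 log units; within the scatter) and a 1.6-fold lower number from compound 3 to compound 4 (0.19 log units; within the scatter) leave compound 4 level with them, so ring size alone does not order the numbers at this position. A pyridine ring alone is also not enough to match compound 1, as (a 4.1-fold higher number from compound 1 to compound 4 (0.61 log units; beyond the scatter)) shows that 5-fluoropyridin-2-yl and 6-aminopyridin-2-yl are not interchangeable here. Nothing available explains these numbers.

Compound 4 and compound 1 differ both in the fluorine and in the amine, and in where each sits, so the compounds shown cannot assign the gap to either group. An unsubstituted pyridin-2-yl or a 5-aminopyridin-2-yl group on the same core would help to separate these contributions.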